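Ester in place of ketone on the dihydropyrimidinone core

The source may report more compounds than this note shows. Statements on the series, on what has been measured and on what is new or still open speak of the compounds shown alone.

Measured compounds:
- compound 1 `CC1=C(C(=O)CC(C)C)C(c2ccco2)NC(=O)N1`: 240 nM
- compound 2 `CC1=C(C(=O)CC(C)C)C(c2ccsc2)NC(=O)N1`: 1000 nM
- compound 3 `CC1=C(c2ncc(C)o2)C(c2ccsc2)NC(=O)N1`: 1130 nM

Of the compounds shown here, three sharing a core have been tested in an assay on membranes from HEK293 cells for displacement of a labelled ligand from adenosine receptor A2b (Homo sapiens), read by scintillation counting, with a stated time of 30 min; a lower number here means a stronger inhibitor, a higher number a weaker inhibitor. Compound 1 gives 240 nM; compound 2 gives 1000 nM; compound 3 gives 1130 nM. Compound 2 stands second highest of the three numbers, with compound 3 nearest and compound 1 furthest away. Exchanging the ring substituent gave a 4.2-fold higher number from compound 1 to compound 2 (0.62 log units; beyond the scatter), while replacing the ketone with an oxazole gave a 1.1-fold higher number from compound 2 to compound 3 (0.05 log units; within the scatter).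

Compound 4 `CC1=C(C(=O)OCC2CC2)C(c2ccsc2)NC(=O)N1` has not yet been measured. It differs from compound 2 by cyclopropylmethoxy in place of isobutyl on a carbonyl carbon, so the carbonyl becomes an ester. Among the compounds with values here, the only step that bears on this position is a 1.1-fold higher number from compound 2 to compound 3 (0.05 log units; within the scatter), which lay within the scatter even though the whole isobutylcarbonyl group was exchanged for a ring. Within the data shown here, no step shows a change at this carbonyl beyond the scatter, and the expectation for compound 4 in this assay is therefore a step of no change at the digits printed from compound 2 to compound 4 (within the scatter), none beyond the scatter. Compound 4 is expected to give 1000 nM, with a range from 400 nM to 2500 nM.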

Compound 4, inhibition constant: 724 nM
Compound 4: middle estimate off by 1.4-fold (0.14 log units), on the high side, within the range that was stated.
By their numbers in this assay, from the lowest: compound 1; then compounds 4, 2 and 3 (each within the scatter of the next).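

In this assay, putting cyclopropylmethoxy in place of isobutyl on a carbonyl carbon, which keeps the carbonyl but turns the ketone into an ester, gave a 1.4-fold lower number from compound 2 to compound 4 (0.14 log units; within the scatter). The earlier step at this place had exchanged the whole isobutylcarbonyl group, whereas this one shows that the group on the carbonyl can take up an oxygen and a three-membered ring with no change beyond the scatter. Nothing measured here offers an explanation for this result.

On these data alone, whether a longer chain in place of cyclopropylmethoxy, an amine on this carbonyl carbon or a carboxylic acid would also stay within the scatter remains open. As far as these compounds go, it also remains open whether the ester would behave the same way with furan-2-yl in place of thiophen-3-yl.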